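This account rests on a few compounds, and the source may have more. Where it says the series, first, only, none or still open, it means among the compounds named here.

Of the compounds shown here, three have been tested so far. Compound 1 `COc1ccc(-c2nc3ccc(F)cc3o2)cc1` and compound 2 `COc1ccc(-c2nc3ccc(F)cc3o2)c(OC)c1` share one core, while compound 3 `COc1cc(OC)cc(-c2nc3cc(F)ccc3s2)c1` is built on a different core; the difference between the two cores is not broken down here. In a functional assay on MCF7 cells (Homo sapiens) for inhibition (a higher number here means a weaker inhibitor, a lower number a stronger inhibitor), compound 1 gives 41000 nM and compound 2 gives 69900 nM. The step between them, (methoxy in place of hydrogen on an aromatic carbon), is a 1.7-fold higher number from compound 1 to compound 2 (0.23 log units; within the scatter). In this assay compound 3 gives 1230 nM, the lowest number of the three, and its gap to compound 1 and to compound 2 lies beyond the scatter.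

The untested compound 4 `COc1cc(-c2nc3cc(F)ccc3s2)cc(OC)c1OC` comes from compound 3 by the same kind of change, (methoxy in place of hydrogen on an aromatic carbon). Around the place the setting differs: in compound 2 the new methoxy group sits ortho to a large group and meta to a methoxy group, whereas in compound 4 it sits ortho to two methoxy groups and para to a large group. Among the compounds with values here, since the only measured instance of this change moved within the scatter, the step from compound 3 to compound 4 is expected to be a 1.2-fold higher number from compound 3 to compound 4 (0.09 log units; within the scatter). Compound 4 is therefore estimated at 1500 nM, with a range from 500 nM to 5000 nM.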

Compound 4, half-maximal inhibitory concentration: 1.9 nM
Compound 4: the middle estimate sits 790-fold (2.90 log units) above what was measured; the measured number lies below the stated range.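

In this assay, methoxy in place of hydrogen on an aromatic carbon gives a 650-fold lower number from compound 3 to compound 4 (2.81 log units; beyond the scatter), and this step does not match the one seen on the other core: the same change on two cores in this assay, a 1.7-fold higher number (0.23 log units; within the scatter) from compound 1 to compound 2 and a 650-fold lower number (2.81 log units; beyond the scatter) from compound 3 to compound 4, 1100-fold (3.04 log units) apart, beyond the scatter of two such steps

In these two pairs, then, the size of the step on one core was no guide to its size on the other, so this change cannot simply be carried across cores in this series. This does not show why the steps differ: the pairs differ in their core and also in the surroundings of the new group, which in compound 4 sits ortho to two methoxy groups and para to a large group, and one pair per core cannot separate these two factors.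

On these data alone, it remains open whether a methoxy group is specifically needed at this place, or whether a hydroxyl group, an ethoxy group or an amine would give a similar result. As far as these compounds go, it is also open what the core of compound 1 would give with the same arrangement of methoxy groups as compound 4.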